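Carbamate alkyl change from compound 3 to compound 4

The source may hold more compounds than are shown below. What is called first, only, known or untested is meant among the compounds shown, and "the series" means these compounds.

Measured so far, with the read-out in a functional assay on CHO-K1 cells with Glucose-dependent insulinotropic receptor (Homo sapiens) as the target, read by a luciferase reporter, with a stated time of 5 h; a lower number here means a smaller maximal response, a higher number a larger maximal response:
compound 1 `CC(C)OC(=O)N1CCC(Oc2cccc3c2CCN3c2ccc(S(C)(=O)=O)cc2F)CC1` gives 62%
compound 2 `CC(C)OC(=O)N1CCC(Oc2ncnc3c2CCN3c2ccc(-c3nccs3)cc2F)CC1` gives 74%
compound 3 `CC(C)(C)OC(=O)N1CCC(Oc2ncnc3c2CCN3c2ccc(S(C)(=O)=O)cc2F)CC1` gives 139%

Compound 3 stands highest of the three numbers. Its nearest neighbour is compound 2, and the gap to it lies beyond the scatter; the gap to compound 1, the furthest, also lies beyond the scatter. Going by the values given here, compounds 1 and 2 each differ from compound 3 in more than one place, so none of these gaps can be read as a single step, and the series so far holds no measured pair that isolates a change at the carbamate ester.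

Compound 4 `CC(C)(C)COC(=O)N1CCC(Oc2ncnc3c2CCN3c2ccc(S(C)(=O)=O)cc2F)CC1` is not yet measured. It differs from compound 3 in one place: neopentyl in place of tert-butyl on an oxygen next to a carbonyl group. The carbamate alkyl grows by one chain carbon, with nothing else moved.

Among the compounds with values here, with no measured step of this kind to lean on, only a modest step is expected in this assay, estimated as a number 24 percentage points lower from compound 3 to compound 4 (beyond the scatter), leaning downward, though a result within the scatter would fit the numbers just as well. For compound 4 the estimate in this assay is 115%, with a range from 70% to 150%.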

Compound 4, largest response reached (reported as percent of maximum), in percent of the reference or control that the assay uses: 80%
Compound 4: middle estimate off by 35 percentage points, on the high side; the measured number falls inside the stated range.
By their numbers in this assay, from the lowest: compound 1; then compounds 2 and 4 (each within the scatter of the next); then compound 3.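

In this assay the series gains its first one-place step, and it falls at the carbamate alkyl: neopentyl in place of tert-butyl gives a number 59 percentage points lower from compound 3 to compound 4 (beyond the scatter) on an oxygen next to a carbonyl group. The largest response reached is therefore sensitive to the alkyl at this position, even though neither group carries a ring, a hydrogen-bond donor, a hydrogen-bond acceptor or a net charge, so the step arises with all of those counts unchanged. Nothing measured here offers a reason for the size of this step.

With only tert-butyl and neopentyl compared on the shared core of compound 3 and compound 4, a single pair cannot show whether the response follows chain length, branching or neither, and an ethyl, a cyclobutyl or a longer straight chain such as n-pentyl on the same oxygen would begin to separate these readings. Going by these compounds, it also remains open whether the same exchange would give a step of similar size on the core of compound 1.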